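Truncating the triazole arm to a hydroxyethyl chain

The compounds below may be only part of what the source reports. "The series", "measured", "known", "first", "only" and "open" are said of these compounds alone.

Measured compounds:
compound 1 `Cc1ccc(S(=O)(=O)NCc2cn(C[C@H](O)[C@H]3OC(=O)C(OCc4ccccc4)=C3OCc3ccccc3)nn2)cc1` — 68000 nM
compound 2 `O=C1O/C(=C\Cn2cc(-c3cc(F)cc(F)c3)nn2)C(OCc2ccccc2)=C1OCc1ccccc1` — "not active" (no number reported)
compound 3 `O=C1O[C@H]([C@@H](O)Cn2cc(CNS(=O)(=O)c3ccc(F)cc3)nn2)C(OCc2ccccc2)=C1OCc1ccccc1` — 34700 nM

The single read-out is a functional assay on CFPAC-1 cells (Homo sapiens) for antiproliferative activity, read by MTT assay, with a stated time of 72 h; a lower number here means a stronger inhibitor, a higher number a weaker inhibitor. Compound 1 stands as the highest of the two numbers; its nearest neighbour is compound 3, and the step of a 2.0-fold lower number from compound 1 to compound 3 (0.29 log units; within the scatter) lies within the scatter, so the two cannot be ordered against each other. Compound 2 returned no number in this assay.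

Compound 4 `O=C1O[C@H]([C@@H](O)Cn2cc(CCO)nn2)C(OCc2ccccc2)=C1OCc1ccccc1` is not yet measured. It differs from compound 1 in one place: hydroxymethyl in place of ((4-methylphenyl)sulfonyl)amino on a saturated chain carbon bound to an aromatic carbon. For the measured compounds named here, no measured step bears directly on this change. Going by the values given here, the only step on record, from compound 1 to compound 3, exchanges a methyl for a fluoro on an aromatic carbon of the group that leaves here, and its size says nothing about removing that group. Compound 2 also lacks the sulfonamide but differs from compound 1 elsewhere as well, so only its lack of a number can be noted.

Among the compounds with values here, both measured numbers are weak, and the change is a large one with no precedent. Compound 4 is expected to remain weak, with a real chance that no number is obtained. The expected step is a 1.2-fold higher number from compound 1 to compound 4 (0.07 log units; within the scatter), with no clear direction beyond the scatter. For compound 4 the estimate is 80000 nM, expected between 30000 nM and 200000 nM.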

Compound 4, half-maximal inhibitory concentration: > 100000 nM
Compound 4: no number, only a limit (the forecaster's own chance of this, stated with the estimate: 35%); middle value at least 1.2-fold (0.09 log units) away from the limit.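

In this assay, compound 4 gives no number, only a limit of the assay: the limit of > 100000 nM in this assay, at which 1 of the 4 values shown sits.

Exchanging ((4-fluorophenyl)sulfonyl)amino for hydroxymethyl on a saturated chain carbon bound to an aromatic carbon gives an at least 2.8-fold higher number from compound 3 to compound 4 (0.45 log units; beyond the scatter), the first step in the series beyond the scatter; the earlier step, a methyl to fluoro exchange on the aromatic ring of this group, had shown no measurable change. The matching exchange of ((4-methylphenyl)sulfonyl)amino gives an at least 1.4-fold higher number from compound 1 to compound 4 (0.16 log units; that floor lies within the scatter), so this pair alone does not establish a loss, and only the comparison with compound 3 shows that this place responds to removing the whole sulfonyl-bearing group.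

The true value of compound 4 lies somewhere past its limit, which leaves the full size of both steps open. On these data alone, it also remains open whether the aromatic ring or the sulfonyl amino link accounts for the difference, and whether a simple amine or a carboxylic acid in place of hydroxymethyl would give a number at this place.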